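This account rests on a few compounds, and the source may have more. Where it says the series, first, only, none or still open, it means among the compounds named here.

Measured in an assay on HEK-293T cells for antagonist activity at vitamin D3 receptor (Homo sapiens), read by a luciferase reporter, with a stated time of 24 h; on this read-out lower numbers stand for stronger inhibition and higher numbers for weaker inhibition:
compound 1 `CC(C)c1onc(-c2c(Cl)cccc2Cl)c1COc1ccc(-c2nc3ccc(C(=O)O)cc3n2CC2CCCCC2)cc1`: 346 nM
compound 2 `CC(C)c1onc(-c2c(Cl)cccc2Cl)c1COc1ccc(-c2nc3ccc(C(=O)O)cc3n2C)c(Cl)c1`: 3520 nM

Compound 2 stands at the higher of the two numbers; in this assay compound 2 gives 3520 nM, while compound 1 gives 346 nM, a gap well beyond the usual scatter. Among the measured compounds shown here, compound 1 and compound 2 differ in two places at once, on the chain carbon bound to the aromatic nitrogen and on the aryl ring of the ether, so no single-change step between measured compounds is available.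

Compound 3 `CC(C)c1onc(-c2c(Cl)cccc2Cl)c1COc1ccc(-c2nc3ccc(C(=O)O)cc3n2CC2CCCCC2)c(Cl)c1` takes up one of these two differences: cyclohexyl in place of hydrogen on a saturated chain carbon bound to an aromatic nitrogen. Compound 3 keeps the chloro-substituted ether aryl of compound 2 and carries the same cyclohexylmethyl group on the aromatic nitrogen as compound 1. For the measured compounds named here, no measured pair isolates this change. The expectation is a step down in this assay from compound 2 to compound 3 of roughly a 5.0-fold lower number from compound 2 to compound 3 (0.70 log units; beyond the scatter), beyond the scatter, with the result expected to sit between the two measured numbers. For compound 3 the estimate in this assay is 700 nM, with a range from 180 nM to 2700 nM.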

Compound 3, half-maximal inhibitory concentration: 160 nM
Compound 3: the middle estimate sits 4.4-fold (0.64 log units) above what was measured; the measured number lies below the stated range.
By their numbers in this assay, from the lowest: compound 3; then compound 1; then compound 2.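

Working in this assay, with the chloro-substituted ether aryl held constant, the change from methyl to cyclohexylmethyl on the saturated chain carbon bound to an aromatic nitrogen now reads cleanly as a single-change step (a large one: a 22-fold lower number from compound 2 to compound 3 (1.34 log units; beyond the scatter)), so this position tolerates the cyclohexyl group and responds strongly to it in this pair. With cyclohexylmethyl held constant, chloro in place of hydrogen on an aromatic carbon gives a far smaller step, modest but still beyond the scatter (a 2.2-fold lower number from compound 1 to compound 3 (0.33 log units; beyond the scatter)), so the lowest number in the set comes with both features present. Nothing measured here explains either step.

Going by these compounds, each step is read against one background only, so it remains open whether the cyclohexyl gain holds without the chloro group, and whether the chloro gain holds with methyl on the aromatic nitrogen. Cyclohexylmethyl is also the only group larger than methyl shown at this position, which leaves open how a benzyl group, a straight butyl chain or a chain ending in an amine would compare.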